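This account rests on a few compounds, and the source may have more. Where it says the series, first, only, none or still open, it means among the compounds named here.

Compound 1 `CC(C)CSc1n[nH]c(-n2[se]c3ccccc3c2=O)n1` gives 37800 nM in a functional assay on A549 cells (Homo sapiens) for antiproliferative activity, read by CCK-8 assay, with a stated time of 48 h; on this read-out lower numbers stand for stronger inhibition and higher numbers for weaker inhibition. Compound 2 `Cc1ccc(CSc2n[nH]c(-n3[se]c4ccccc4c3=O)n2)cc1` reaches only the limit of this assay there, > 50000 nM. The step of an at least 1.3-fold higher number from compound 1 to compound 2 (0.12 log units; that floor lies within the scatter) is therefore known only as a floor, set by the limit of > 50000 nM in this assay, at which 1 of the 2 values shown sits. Compound 3 `Cc1cccc(CSc2n[nH]c(-n3[se]c4ccccc4c3=O)n2)c1` is still unmeasured; it differs from compound 2 by 3-methylphenyl in place of 4-methylphenyl on a saturated chain carbon bound to a sulfur. Within the data shown here, the one measured step swapped an isopropyl for a 4-methylphenyl, not one methylphenyl for another, so it offers little guidance on this change. The step that the limit leaves unreadable from compound 2 to compound 3 is expected to stay within the scatter. Compound 3 is thus estimated at 60000 nM, between 30000 nM and 150000 nM.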

Compound 3, half-maximal inhibitory concentration: 12400 nM
Beside the measured number, compound 3's estimate is 4.8-fold (0.68 log units) above it, and the stated range ends above it.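

Which ring carbon holds the methyl matters at this place: an at least 4.0-fold lower number from compound 2 to compound 3 (0.60 log units; beyond the scatter). A methylphenyl group is therefore not unfavourable here in itself, as the comparison with the isopropyl compound reads a 3.0-fold lower number from compound 1 to compound 3 (0.48 log units; beyond the scatter). Compound 2 sits at a limit, so the size of its step to compound 3 is known only as a floor: the limit of > 50000 nM in this assay, at which 1 of the 3 values shown sits.

As far as these compounds go, whether a 3-chlorophenyl or 3-methoxyphenyl group in the same place would match or exceed the 3-methylphenyl group stays open.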